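Working notes: the step from compound 3 to compound 4

The compounds below may be only part of what the source reports. "The series", "measured", "known", "first", "only" and "open" are said of these compounds alone.

Measured so far in a functional assay on DU-145 cells (Homo sapiens) for cytotoxicity, read by trypan blue exclusion, with a stated time of 96 h (a lower number here means a stronger inhibitor, a higher number a weaker inhibitor), as follows:
- compound 1 `COc1cc(OC)c(/C=C/S(=O)(=O)Cc2ccc(OC)c([N+](=O)[O-])c2)c(OC)c1` gives 2500 nM
- compound 2 `COC(=O)[C@H](C)Nc1cc(CS(=O)(=O)/C=C/c2c(OC)cc(OC)cc2OC)ccc1OC` gives 750 nM
- compound 3 `COC(=O)C(F)(F)Nc1cc(CS(=O)(=O)/C=C/c2c(OC)cc(OC)cc2OC)ccc1OC` gives 250 nM

Compound 3 stands lowest of the three in this assay at 250 nM on these numbers. Compound 4 `COC(=O)C(Nc1cc(CS(=O)(=O)/C=C/c2c(OC)cc(OC)cc2OC)ccc1OC)c1ccc(F)cc1` is still unmeasured. Its difference is (4-fluorophenyl)(methoxycarbonyl)methyl in place of difluoro(methoxycarbonyl)methyl on a nitrogen on an aromatic ring in short, (4-fluorophenyl)(methoxycarbonyl)methyl in place of difluoro(methoxycarbonyl)methyl on a nitrogen on an aromatic ring.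

The closest evidence is a change at the same nitrogen, a 3.0-fold lower number from compound 2 to compound 3 (0.48 log units; beyond the scatter) in all, which is modest. The replacements of nitro, a 3.3-fold lower number from compound 1 to compound 2 (0.52 log units; beyond the scatter) and a 10-fold lower number from compound 1 to compound 3 (1.00 log units; beyond the scatter) here, are also modest. Among the measured compounds shown here, no measured compound carries an aromatic ring in this group, so the direction is poorly defined. A small move towards a higher number is expected, since compound 3 already holds the lowest value at 250 nM so far. The estimated change is a 1.4-fold higher number from compound 3 to compound 4 (0.15 log units; within the scatter) on this reasoning. For compound 4 the expected value is 350 nM within an estimated range of 100 nM to 1200 nM overall.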

Compound 4, half-maximal inhibitory concentration: 300 nM
Compound 4: middle estimate off by 1.2-fold (0.07 log units), on the high side; low and high end bracket the measured number.
By their numbers in this assay, from the lowest: compounds 3 and 4 (each within the scatter of the next); then compound 2; then compound 1.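

In this assay, the nitrogen on an aromatic ring accepts a substituent carrying an aromatic ring: (4-fluorophenyl)(methoxycarbonyl)methyl in place of difluoro(methoxycarbonyl)methyl gives a 1.2-fold higher number from compound 3 to compound 4 (0.08 log units; within the scatter). In place of 1-(methoxycarbonyl)ethyl, the same group gives a 2.5-fold lower number from compound 2 to compound 4 (0.40 log units; beyond the scatter), so the gain seen with the difluoro group is not confined to that group, and a larger group with a six-membered aromatic ring fits at this place without a loss beyond the scatter. No measurement at hand indicates what lies behind these two groups reading alike.

Still open, as far as these compounds go, is whether the methoxycarbonyl is needed, as compound 2, compound 3 and compound 4 all carry it; a carboxylic acid or a primary amide in its place would test this. Also open, from the compounds shown here alone, is what the ring fluorine contributes, which an unsubstituted phenyl would show.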